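This account rests on a few compounds, and the source may have more. Where it says the series, first, only, none or still open, it means among the compounds named here.

Compound 1 `COc1ccc2c(=O)c(/C=C/C(=O)NCc3cccc(F)c3)coc2c1` gives 17600 nM in a functional assay on HeLa cells (Homo sapiens) for inhibition, read by MTT assay, with a stated time of 48 h; a lower number here means a stronger inhibitor, a higher number a weaker inhibitor. Compound 2 `COc1ccc2c(=O)c(/C=C/C(=O)Nc3ccccc3OC)coc2c1` reaches only the assay limit of > 100000 nM. Compound 3 `COc1ccc2c(=O)c(/C=C/C(=O)Nc3ccccc3C)coc2c1` gives 7270 nM.

Among the two numbers shown, compound 3 stands lowest; its nearest neighbour is compound 1, with a 2.4-fold lower number from compound 1 to compound 3 (0.38 log units; beyond the scatter). The value of compound 2 is a limit, not a number (the limit of > 100000 nM in this assay, at which 1 of the 3 values shown sits).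

Compound 4 `CCOc1ccc(NC(=O)/C=C/c2coc3cc(OC)ccc3c2=O)cc1` differs from compound 3 in one place: 4-ethoxyphenyl in place of 2-methylphenyl on an amide-type nitrogen. Among the measured compounds shown here, two measured steps bear on this. Replacing the 3-fluorobenzyl by 2-methylphenyl gave a 2.4-fold lower number from compound 1 to compound 3 (0.38 log units; beyond the scatter), whereas the alkoxy-bearing aryl of compound 2 sat at the limit, and an at least 13-fold lower number from compound 2 to compound 3 (1.13 log units; beyond the scatter). An alkoxy group returns in compound 4, so a higher number is expected, a 4.1-fold higher number from compound 3 to compound 4 (0.62 log units; beyond the scatter). Compound 4 is estimated at 30000 nM, between 8000 nM and 100000 nM.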

Compound 4, half-maximal inhibitory concentration: > 100000 nM
Compound 4: a limit, no number (the forecaster's own chance of this, stated with the estimate: 30%); at least 3.3-fold (0.52 log units) between middle value and limit.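

Compound 4 is a second alkoxy-bearing aryl amide to sit at a limit rather than a number in this assay, so this outcome is not confined to the 2-methoxyphenyl group: the limit of > 100000 nM in this assay, at which 2 of the 4 values shown sit.
Against both compounds with a readable value, the 4-ethoxyphenyl group leaves a clear loss: an at least 13-fold higher number from compound 3 to compound 4 (1.13 log units; beyond the scatter) and an at least 5.6-fold higher number from compound 1 to compound 4 (0.75 log units; beyond the scatter).
The step between compound 2 and compound 4 cannot be read, as both are limits.

As far as these compounds go, it remains open whether a 4-methylphenyl group would keep a readable value. Also open, from the compounds shown here alone, is how a phenyl ring carrying a hydroxy group or an amine would compare.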